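The source may hold more compounds than are shown below. What is called first, only, known or untested is meant among the compounds shown, and "the series" means these compounds.

Measured compounds:
compound 1 `COc1cc(C(=O)c2sc(-c3ccccc3Cl)cc2N)cc(OC)c1OC` — 20 nM
compound 2 `COc1cc(C(=O)c2sc(-c3ccc(Cl)c(Cl)c3)cc2N)cc(OC)c1OC` — 260 nM

In a functional assay on L1210 cells (Mus musculus) for antiproliferative activity (on this read-out lower numbers stand for stronger inhibition and higher numbers for weaker inhibition), compound 1 gives 20 nM, and compound 2 gives 260 nM. Of these two numbers, compound 2 holds the highest, meaning the weaker inhibition; its nearest neighbour is compound 1, and the step between them, a 13-fold higher number from compound 1 to compound 2 (1.11 log units; beyond the scatter), lies beyond the scatter.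

Compound 3 `COc1cc(C(=O)c2sc(-c3ccc(C(F)(F)F)cc3)cc2N)cc(OC)c1OC` has not yet been measured. It differs from compound 2 in one place: 4-(trifluoromethyl)phenyl in place of 3,4-dichlorophenyl on an aromatic carbon.

Going by the values given here, only one measured step bears on this change, and it was large: a 13-fold higher number from compound 1 to compound 2 (1.11 log units; beyond the scatter). That step shows that the aryl group at this position of the shared core can move the number a good deal. It compares a 2-chlorophenyl with a 3,4-dichlorophenyl, whereas compound 3 carries a 4-(trifluoromethyl)phenyl that neither measured compound holds, so the direction for compound 3 is uncertain. Compound 3 is expected to give about 150 nM, with a likely range of 40 nM to 600 nM. The expected step of a 1.7-fold lower number from compound 2 to compound 3 (0.24 log units; within the scatter) is toward a lower number, but small enough that it may fall within the scatter.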

Compound 3, half-maximal inhibitory concentration: 370 nM
For compound 3 the middle estimate is 2.5-fold (0.39 log units) below the measured one; measured number inside the range.
By their numbers in this assay, from the lowest: compound 1; then compounds 2 and 3 (each within the scatter of the next).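

In this assay there is a 1.4-fold higher number from compound 2 to compound 3 (0.15 log units; within the scatter) when 4-(trifluoromethyl)phenyl replaces 3,4-dichlorophenyl on this aromatic carbon next to the ring sulfur, so the two groups cannot be told apart here even though their atoms differ. The comparison with the first compound shows a 19-fold higher number from compound 1 to compound 3 (1.27 log units; beyond the scatter) and is large, as is a 13-fold higher number from compound 1 to compound 2 (1.11 log units; beyond the scatter) in the earlier pair. The large step therefore no longer rests on a single pair: two different aryl groups give numbers within the scatter of each other, and the 2-chlorophenyl of compound 1 alone stands apart with the stronger inhibition. Nothing available here explains why these groups differ in this way.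

These three compounds cannot show whether the 2-chlorophenyl group is unusual or whether an unsubstituted phenyl ring or a methoxyphenyl group would also give a low number. They also leave open how this position would respond to a phenyl ring carrying an amine or a carboxylic acid, or to a longer alkyl chain in place of the aryl ring.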